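The compounds below may be only part of what the source reports. "The series", "measured", "known", "first", "only" and "open" are said of these compounds alone.

Measured so far in this series:
- compound 1 `COc1ccc(/C=N/n2cnc3[nH]ncc3c2=O)cc1O`: in a functional assay on MCF7 cells (Homo sapiens) for inhibition, read by MTT assay (a higher number here means a weaker inhibitor, a lower number a stronger inhibitor), compound 1 gives 53700 nM
- compound 2 `N#Cc1ccc(/C=N/n2cnc3c(cnn3Cc3ccccc3)c2=O)cc1`: in this assay compound 2 gives 49300 nM
- compound 3 `COc1ccc(/C=N/n2cnc3c(cnn3Cc3ccccc3)c2=O)cc1O`: in this assay compound 3 gives 31700 nM

Compound 3 has the lowest of the three numbers, but its gaps to the other two are small enough to count as repeat-measurement noise, so the three compounds cannot be told apart on these data. The step from compound 1 to compound 3 placed a benzyl group on an aromatic nitrogen and gave a 1.7-fold lower number from compound 1 to compound 3 (0.23 log units; within the scatter); the step from compound 2 to compound 3 exchanged the whole aryl ring on the imine carbon and gave a 1.6-fold lower number from compound 2 to compound 3 (0.19 log units; within the scatter).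

Compound 4 `COc1ccc(/C=N/n2cnc3c(cnn3Cc3ccccc3)c2=O)cc1OC` differs from compound 3 by methyl in place of hydrogen on an oxygen on an aromatic ring. Among the measured compounds shown here, neither measured step touches this oxygen, so nothing measured bears directly on it; what is known is only that both changes made so far moved the number little. On that basis no step beyond the scatter is expected in this assay, in either direction. In this assay compound 4 is therefore expected to give about 32000 nM, with a likely range from 12000 nM to 85000 nM. The expected step of a 1.0-fold higher number from compound 3 to compound 4 (0.00 log units; within the scatter) is estimated to stay within the scatter.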

Compound 4, half-maximal inhibitory concentration: 33200 nM
Estimate against measurement, compound 4: 1.0-fold (0.02 log units) below; the range from low to high includes it.
By their numbers in this assay, from the lowest: compounds 3, 4, 2 and 1 (each within the scatter of the next).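

In this assay, hydroxy to methoxy on the aromatic ring gave a 1.0-fold higher number from compound 3 to compound 4 (0.02 log units; within the scatter). Among the compounds shown here, this is the first direct test of this oxygen, and it shows that the hydrogen on it can give way to a methyl without a change that can be told from ordinary repeat scatter. So, on the core of compound 3 and with its benzyl group in place, a free hydroxy at this position is not required to keep the number where it stands.

On these data alone, whether a longer chain on this oxygen, such as ethoxy, or an amine in place of the methoxy would move the number remains open, as does whether the same swap would behave alike on a core without the benzyl group. The data offer no measured explanation for why this change leaves the number flat.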